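Furan-to-imidazole swap at the biaryl position of compound 3

This account rests on a few compounds, and the source may have more. Where it says the series, first, only, none or still open, it means among the compounds named here.

Measured compounds in a functional assay for activation of Alpha-1B adrenergic receptor (Homo sapiens), read by calcium flux; on this read-out higher numbers stand for an effect only at larger amounts of compound and lower numbers for an effect already at smaller amounts:
- compound 1 `c1ccc(-c2cnccn2)c(OCC2=NCCN2)c1` gives 631 nM
- compound 2 `c1coc(-c2ccccc2OCC2=NCCN2)c1` gives 10 nM
- compound 3 `c1ccc(-c2ccoc2)c(OCC2=NCCN2)c1` gives 5.01 nM

Compound 3 has the lowest number of the three; compound 2 is within the scatter of it, while compound 1 stands far higher, a 130-fold lower number from compound 1 to compound 3 (2.10 log units; beyond the scatter). The two five-membered rings behave alike, a 2.0-fold lower number from compound 2 to compound 3 (0.30 log units; within the scatter), and both are far from the six-membered two-nitrogen ring: a 63-fold lower number from compound 1 to compound 2 (1.80 log units; beyond the scatter) and a 130-fold lower number from compound 1 to compound 3 (2.10 log units; beyond the scatter).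

Compound 4 `c1ccc(-c2ncc[nH]2)c(OCC2=NCCN2)c1` carries the change (1H-imidazol-2-yl in place of furan-3-yl on an aromatic carbon). The entering ring is five-membered like furan, but holds two hetero atoms like pyrazine and adds a hydrogen-bond donor. Among the measured compounds shown here, no measured step covers this exact exchange; the steps from compound 1 to compounds 2 and 3 show how much the ring identity at this place can move the number. The expectation for compound 4 in this assay is therefore a higher number than compound 3, with wide uncertainty, estimated as a 16-fold higher number from compound 3 to compound 4 (1.20 log units; beyond the scatter). The estimated value for compound 4 is 80 nM, range 10 nM to 600 nM.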

Compound 4, half-maximal effective concentration: < 100000 nM
Compound 4 ended at the assay's limit; the forecaster's own chance of this, stated with the estimate: 5%; the middle value lies beyond the limit too.
By their numbers in this assay, from the lowest: compounds 3 and 2 (each within the scatter of the next); then compound 1.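

Compound 4 gives < 100000 nM, which is a limit of the assay and not a number. The steps to compound 4 from compound 1, compound 2 and compound 3 therefore cannot be read. The compounds shown leave open how 1H-imidazol-2-yl ranks against furan-3-yl, furan-2-yl and pyrazin-2-yl at this place.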